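This account rests on a few compounds, and the source may have more. Where it says the series, first, only, none or still open, it means among the compounds named here.

Among the measured compounds shown here, compound 1 `COc1ncnc2c1c(-c1cccs1)cn2[C@@H]1O[C@H](CO)[C@@H](O)[C@H]1O` is the only compound here with a measured number: in a functional assay on CCRF-CEM cells (Homo sapiens), read by MTT assay, with a stated time of 72 h (on this read-out higher numbers stand for weaker inhibition and lower numbers for stronger inhibition), compound 1 gives 90 nM. Compound 2 `CNc1ncnc2c1c(-c1cccs1)cn2[C@@H]1O[C@H](CO)[C@@H](O)[C@H]1O` reaches only a limit of this assay, > 20000 nM. For the measured compounds named here, the one measured step, an at least 220-fold higher number from compound 1 to compound 2 (2.34 log units; beyond the scatter), changes the group on the six-membered ring and so does not bear on the change to compound 3 `COc1ncnc2c1c(I)cn2[C@@H]1O[C@H](CO)[C@@H](O)[C@H]1O`, which is iodo in place of thiophen-2-yl on an aromatic carbon. Going by the values given here, with no measured step bearing on it, no direction beyond the scatter is expected from compound 1 to compound 3, though a modest loss is possible. Compound 3 is estimated at 150 nM (range 30 nM to 1500 nM), that is a 1.7-fold higher number from compound 1 to compound 3 (0.22 log units; within the scatter).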

Compound 3, half-maximal inhibitory concentration: 1150 nM
The estimate for compound 3 lay 7.7-fold (0.88 log units) below the measured number; low and high end bracket the measured number.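

Iodo in place of thiophen-2-yl gives a 13-fold higher number from compound 1 to compound 3 (1.11 log units; beyond the scatter) in this assay, so the group on this aromatic carbon of the five-membered ring also governs the read-out, which the earlier step, on the six-membered ring, could not show. The exchange of this one group is enough for a large loss, although compound 3 still gives a measured number. Nothing shown here gives a cause for this step. Going by these compounds, what a phenyl, a furan-2-yl or a methyl group on this carbon would give stays open. So does the effect of iodo when methylamino replaces methoxy.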